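The compounds below may be only part of what the source reports. "The series", "measured", "known", "first", "only" and "open" are said of these compounds alone.

Working notes on the series. Of the compounds shown here, three have been measured in a functional assay on UACC-257 cells (Homo sapiens) for inhibition; a higher number here means a weaker inhibitor of growth, a lower number a stronger inhibitor of growth. Compound 1 `COc1cc(/C=C/C(=O)c2cccc(-n3cc(-c4ccc(Cl)cc4)[nH]c3=O)c2)cc(OC)c1OC` gives 17400 nM. Compound 2 `COc1cc(/C=C/C(=O)c2cccc(-n3cc(-c4ccccc4)[nH]c3=O)c2)ccc1O` gives 6810 nM. Compound 3 `O=C(/C=C/c1cccc(O)c1)c1cccc(-n2cc(-c3ccccc3)[nH]c2=O)c1` gives 7680 nM, which is the second highest of the three numbers: compound 2 sits nearest, and the step of a 1.1-fold higher number from compound 2 to compound 3 (0.05 log units; within the scatter) lies within the scatter, while compound 1 sits furthest, with a number beyond the scatter above compound 3.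

Compound 4 `O=C(/C=C/c1cccc(O)c1)c1cccc(-n2cc(-c3ccc(Cl)cc3)[nH]c2=O)c1` is the next member. It differs from compound 3 by chloro in place of hydrogen on an aromatic carbon, on an aromatic carbon of a six-membered aromatic ring of carbon only, para to a large group; cut one bond further out, the change reads phenyl to 4-chlorophenyl.

Within the data shown here, no measured pair isolates this change. Compound 1 carries the 4-chlorophenyl and gives the highest number of the set, but it differs from compound 2 in two places at once, so its gap to compound 2 cannot be laid on the chloro alone. Among the measured compounds shown here, the one clean step, from compound 2 to compound 3, concerns the other end of the molecule and is within the scatter, so it says nothing about the chloro.

The expectation for compound 4 is therefore a small upward step, a 1.4-fold higher number from compound 3 to compound 4 (0.14 log units; within the scatter), weighted by the number of compound 1 17400 nM but held close to compound 3 given the lack of a direct comparison. Compound 4 is estimated at 10500 nM, within the range 4500 nM to 25000 nM.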

Compound 4, concentration for 50% growth inhibition: 4070 nM
Compound 4: middle estimate off by 2.6-fold (0.41 log units), on the high side; measured number outside the range, below it.
By their numbers in this assay, from the lowest: compounds 4, 2 and 3 (each within the scatter of the next); then compound 1.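

In this assay the step from phenyl to 4-chlorophenyl can now be read on its own, and chloro in place of hydrogen on this aromatic carbon, para to a large group, gives a 1.9-fold lower number from compound 3 to compound 4 (0.28 log units; within the scatter), so this single change leaves the number inside the usual spread of repeats. This also separates the chloro from the high number of compound 1: compound 1 gives 17400 nM in this assay and compound 4, which carries the same 4-chlorophenyl and differs only in having a 3-hydroxyphenyl in place of the methoxy-bearing phenyl, gives 4070 nM, so with the chloro held fixed the two numbers still stand apart and the 4-chlorophenyl alone does not go with a high number in this pair. No measurement in hand speaks to the origin of either result.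

Open, going by these compounds, is whether fluoro, bromo, methoxy or an amine on the same aromatic carbon would give a step beyond the scatter, or whether a carboxylic acid there would. Also open, on these data alone, is whether the chloro gives a comparable step alongside the 4-hydroxy-3-methoxyphenyl of compound 2.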